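Replacing the Chlorophenyl Urea Terminus with a Dimethylphenyl Group

This account rests on a few compounds, and the source may have more. Where it says the series, first, only, none or still open, it means among the compounds named here.

Compound 1 `O=C(Nc1ccc(Cl)cc1)Nc1cccc(CNc2nccnc2Cl)c1` — 8350 nM
Compound 2 `CN(C)c1ccc(NC(=O)Nc2cccc(CNc3nccnc3Cl)c2)cc1` — > 40000 nM
Compound 3 `O=C(Nc1cccc(CNc2nccnc2Cl)c1)NC1CCCC1` — 18400 nM

Three ureas sharing one core were measured in a functional assay on HepG2 cells (Homo sapiens) for antiproliferative activity, read by MTT assay, with a stated time of 48 h; on this read-out higher numbers stand for weaker inhibition and lower numbers for stronger inhibition. Compound 1 gives 8350 nM in this assay and stands lowest of the two numbers shown; its nearest neighbour is compound 3, with a 2.2-fold higher number from compound 1 to compound 3 (0.34 log units; beyond the scatter). For compound 2 the result in this assay is only a limit, > 40000 nM, (the limit of > 40000 nM in this assay, at which 1 of the 3 values shown sits); against compound 1 this reads as an at least 4.7-fold higher number from compound 1 to compound 2 (0.68 log units; beyond the scatter).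

Compound 4 `Cc1ccc(NC(=O)Nc2cccc(CNc3nccnc3Cl)c2)cc1C` has not yet been measured. It differs from compound 1 in one place: 3,4-dimethylphenyl in place of 4-chlorophenyl on an amide-type nitrogen. Two measured steps start from the same position. The dimethylamino-bearing ring of compound 2 gave an at least 4.7-fold higher number from compound 1 to compound 2 (0.68 log units; beyond the scatter), and the cyclopentyl of compound 3 gave a 2.2-fold higher number from compound 1 to compound 3 (0.34 log units; beyond the scatter). Every change away from the 4-chlorophenyl group of compound 1 so far has weakened inhibition, so a higher number is expected for compound 4, but a dimethylphenyl ring stays closer to the chlorophenyl than either of those groups, so the step is expected to be small. Compound 4 is therefore estimated at 11000 nM in this assay, within 4500 nM to 30000 nM, a step of a 1.3-fold higher number from compound 1 to compound 4 (0.12 log units; within the scatter).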

Compound 4, half-maximal inhibitory concentration: 10700 nM
Compound 4: middle estimate off by 1.0-fold (0.01 log units), on the high side, and the stated range covers the measured number.
By their numbers in this assay, from the lowest: compounds 1, 4 and 3 (each within the scatter of the next, the first and the last beyond it). At a limit, above all of these: compound 2.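

In this assay, for the compounds shown here, the 3,4-dimethylphenyl group is the first replacement on the amide-type nitrogen that stays within the scatter of the 4-chlorophenyl group, with a 1.3-fold higher number from compound 1 to compound 4 (0.11 log units; within the scatter), so a ring carrying no chlorine can hold this position without a clear loss. The same ring also stays within the scatter of the cyclopentyl group, with a 1.7-fold lower number from compound 3 to compound 4 (0.24 log units; within the scatter), which leaves this result unseparated from either neighbour even though those two neighbours are separated from each other. A phenyl ring on this nitrogen does not by itself keep the number in this range, with an at least 3.7-fold lower number from compound 2 to compound 4 (0.57 log units; beyond the scatter) for the 4-(dimethylamino)phenyl ring, and that step rests on a limit: the limit of > 40000 nM in this assay, at which 1 of the 4 values shown sits.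

Going by these compounds, it remains open whether a single methyl, as in a 4-methylphenyl group, would read like the 3,4-dimethylphenyl group, and how a 4-methoxyphenyl or 4-fluorophenyl group would fall. The shared core is the same throughout, so the compounds shown say nothing about a bromo or methoxy group in place of its chlorine.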